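Trading a Saturated Ring for Benzyl at the Ether Oxygen

This account rests on a few compounds, and the source may have more. Where it says the series, first, only, none or still open, it means among the compounds named here.

Three measured compounds share one core and differ only in the group attached to one aromatic carbon. Compound 3 `CC(C(=O)NCc1ccc(C(F)(F)Cl)nc1OC1CCCCC1)c1ccc(NS(C)(=O)=O)c(F)c1` carries a cyclohexyloxy group there, and in an assay on CHO cells for antagonist activity at transient receptor potential cation channel subfamily V member 1 (Homo sapiens), read by FLIPR (on this read-out higher numbers stand for weaker inhibition and lower numbers for stronger inhibition), compound 3 gives 0.9 nM. Its number is the second highest of the three: compound 1 `CC(C(=O)NCc1ccc(C(F)(F)Cl)nc1N1CCCCC1)c1ccc(NS(C)(=O)=O)c(F)c1` gives 1.3 nM, and compound 2 `CC(C(=O)NCc1ccc(C(F)(F)Cl)nc1N1CCCCCC1)c1ccc(NS(C)(=O)=O)c(F)c1` gives 0.5 nM. The gaps are a 1.4-fold lower number from compound 1 to compound 3 (0.16 log units; within the scatter) and a 1.8-fold higher number from compound 2 to compound 3 (0.26 log units; within the scatter), so compound 3 cannot be separated from either neighbour. Compound 4 `CC(C(=O)NCc1ccc(C(F)(F)Cl)nc1OCc1ccccc1)c1ccc(NS(C)(=O)=O)c(F)c1` keeps the ether oxygen of compound 3 and changes what hangs on it: benzyl in place of cyclohexyl on an oxygen on an aromatic ring. Among the measured compounds shown here, none of the measured steps touches this position; they all replace the whole group on the aromatic carbon, the largest being a 2.6-fold lower number from compound 1 to compound 2 (0.41 log units; beyond the scatter), a modest move. For the measured compounds named here, with no direct precedent, the change from compound 3 to compound 4 is expected to be small, with a 1.3-fold higher number from compound 3 to compound 4 (0.12 log units; within the scatter) lying within the scatter. Compound 4 is therefore estimated at 1.2 nM, with a likely range from 0.4 nM to 3.5 nM.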

Compound 4, inhibition constant: 0.9 nM
Beside the measured number, compound 4's estimate is 1.3-fold (0.12 log units) above it; the range from low to high includes it.
By their numbers in this assay, from the lowest: compounds 2, 3, 4 and 1 (each within the scatter of the next, the first and the last beyond it).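

Among the compounds shown here, replacing cyclohexyl with benzyl on the oxygen gives no change at the digits printed from compound 3 to compound 4 (within the scatter) and is the first change here that leaves the ether oxygen in place, so a saturated ring and an aromatic ring attached through one extra carbon cannot be told apart at this position. The other two steps, a 1.8-fold higher number from compound 2 to compound 4 (0.26 log units; within the scatter) and a 1.4-fold lower number from compound 1 to compound 4 (0.16 log units; within the scatter), show that compound 4 cannot be separated from either nitrogen-linked compound, even though those two compounds are separated from each other. No measurement here explains why the two oxygen substituents read alike.

The compounds shown leave open how far this tolerance extends on the oxygen. A longer chain such as phenethyl, a small group such as methyl, or a benzyl carrying a chlorine or a carboxylic acid could each test that limit.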